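A propanoyl-to-methyl swap on compound 2

The source may hold more compounds than are shown below. What is called first, only, known or untested is meant among the compounds shown, and "the series" means these compounds.

- compound 1 `O=C(OCc1ccccc1)[C@@H]1COC(c2ccccc2)=N1` gives 2.8%
- compound 2 `CCC(=O)c1ccccc1OC(=O)c1coc(-c2ccccc2)n1` gives 8.7%

Both numbers come from an ADME assay on microsomes from liver (Rattus norvegicus, strain Sprague-Dawley) for metabolic stability, read by LC-MS, with a stated time of 15 min, tested at 20 uM (on this read-out higher numbers stand for a more stable compound and lower numbers for a less stable compound), and they are all that has been measured so far. In this assay compound 2 gives 8.7% and compound 1 gives 2.8% so the two lie within the usual scatter of each other and neither can be ranked above the other. Within the data shown here, the two compounds do not differ in just one place, so no measured step is available as a guide. Compound 3 `Cc1ccccc1OC(=O)c1coc(-c2ccccc2)n1` is the next to be measured. Its change from compound 2 methyl in place of propanoyl on an aromatic carbon is methyl in place of propanoyl on an aromatic carbon, ortho to a large group. Compound 2 at 8.7% leaves little room for a fall. The estimated step of a number 2.7 percentage points lower from compound 2 to compound 3 (within the scatter) is expected to be small, slightly downward and within the scatter. Compound 3 is expected at 6% with an estimated range of 1% to 20% in this assay.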

Compound 3, percent of the compound remaining: 13.4%
The estimate for compound 3 lay 7.4 percentage points below the measured number; low and high end bracket the measured number.
By their numbers in this assay, from the lowest: compounds 1, 2 and 3 (each within the scatter of the next, the first and the last beyond it).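

In this assay, among these compounds, methyl in place of propanoyl on an aromatic carbon, ortho to a large group, gives a number 4.7 percentage points higher from compound 2 to compound 3 (within the scatter), the first step that can be read at this position. The propanoyl, with its carbonyl and its hydrogen-bond acceptor, can therefore give way to a single methyl while compound 2 and compound 3 stay within the scatter of each other, so this read-out does not separate the two groups. Nothing available bears on the cause of this result.

Going by these compounds, whether an amine, a carboxylic acid or a longer chain at this position would give a step beyond the scatter remains open. Also open, on these data alone, is whether the same swap would read alike on a different core, since this single step comes from one pair of compounds.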